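Adding a third methoxy group: what the chalcone series suggests

This account rests on a few compounds, and the source may have more. Where it says the series, first, only, none or still open, it means among the compounds named here.

Of the compounds shown here, three sharing one core have been tested in a functional assay on A549 cells (Homo sapiens) for antiproliferative activity, read by MTT assay, with a stated time of 24 h (on this read-out higher numbers stand for weaker inhibition and lower numbers for stronger inhibition), and all three give numbers of the same order. Compound 1 `COc1ccc(-c2cc(/C=C/C(=O)c3ccc(C)cc3)nc3cc(-c4ccccc4)nn23)cc1OC` gives 17200 nM in this assay. Compound 2 `COc1ccc(/C=C/C(=O)c2cc(-c3cc(OC)c(OC)c(OC)c3)n3nc(-c4ccccc4)cc3n2)cc1OC` gives 20500 nM, and compound 3 `COc1ccc(C(=O)/C=C/c2cc(-c3cc(OC)c(OC)c(OC)c3)n3nc(-c4ccccc4)cc3n2)cc1OC` gives 17800 nM. Among these three numbers the one for compound 2 is the highest, but the numbers of compound 1 and compound 3 both lie within the usual scatter of it, so nothing separates the three compounds on this read-out.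

Compound 4 `COc1cc(/C=C/C(=O)c2cc(-c3cc(OC)c(OC)c(OC)c3)n3nc(-c4ccccc4)cc3n2)cc(OC)c1OC` is not yet measured. It differs from compound 2 in one place: methoxy in place of hydrogen on an aromatic carbon. For the measured compounds named here, no pair of measured compounds that differ in only one place is available, so there is no measured step to lean on for this change. What the three measured compounds do show is that changes of this kind across the series have left the numbers close together, and the same is expected here: in this assay the step of a 1.1-fold lower number from compound 2 to compound 4 (0.06 log units; within the scatter) is expected to stay within the scatter, in no clear direction. Compound 4 is therefore estimated at 18000 nM, with a plausible range from 8000 nM to 40000 nM.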

Compound 4, half-maximal inhibitory concentration: 25900 nM
Compound 4: middle estimate off by 1.4-fold (0.16 log units), on the low side; the range from low to high includes it.
By their numbers in this assay, from the lowest: compounds 1, 3, 2 and 4 (each within the scatter of the next).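

For the compounds shown here, the change from 3,4-dimethoxyphenyl to 3,4,5-trimethoxyphenyl provides the first measured step between two compounds that differ in only one place: in this assay, the result is a 1.3-fold higher number from compound 2 to compound 4 (0.10 log units; within the scatter). On this read-out, then, a methoxy group in place of hydrogen at this position, ortho to one methoxy group and meta to another, produces no change that can be told apart from the variation between repeated measurements, although this rests on a single pair of compounds. No supporting measurement bears on how this result should be explained.

The compounds shown leave open whether a different group at this same position, such as an amine, a carboxylic acid, a fluorine atom or a longer chain like ethoxy, would shift the number beyond the scatter. They also leave open whether methoxy in place of hydrogen would give a similarly small step on a different aromatic ring of the shared core, or on a compound whose other groups differ from those of compound 2.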